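Carbamate to pivalamide variation on a biaryl dimethylaniline series

This account rests on a few compounds, and the source may have more. Where it says the series, first, only, none or still open, it means among the compounds named here.

Measured so far, in an assay on COS-7 cells for inhibition of patatin-like phospholipase domain-containing protein 2 (Mus musculus); a lower number here means a stronger inhibitor, a higher number a weaker inhibitor:
compound 1, `CN(C)C(=O)Nc1cccc(-c2ccc(N(C)C)cc2)c1`, gives < 5000 nM, which is a limit of the assay rather than a number.
compound 2, `CCOC(=O)Nc1cccc(-c2ccc(N(C)C)cc2)c1`, gives 3000 nM.
compound 3, `CC(C)COC(=O)Nc1cccc(-c2ccc(N(C)C)cc2)c1`, gives 22000 nM.

Compound 3 holds the highest of the two numbers; the nearest is compound 2, with a 7.3-fold higher number from compound 2 to compound 3 (0.87 log units; beyond the scatter). Compound 1 sits at a limit (the limit of < 5000 nM in this assay, at which 1 of the 3 values shown sits), so a step that the limit leaves unreadable from compound 1 to compound 2 and only a bound is readable for an at least 4.4-fold higher number from compound 1 to compound 3 (0.64 log units; beyond the scatter). Both readable steps point the same way: growing the group on the carbonyl carbon from ethoxy or dimethylamino to isobutoxy raised the number in this assay.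

Compound 4, `CN(C)c1ccc(-c2cccc(NC(=O)C(C)(C)C)c2)cc1`, is the next compound to be measured. Relative to compound 3 the change is tert-butyl in place of isobutoxy on a carbonyl carbon. Going by the values given here, of the measured steps, 2>3 bears most on it, since compound 4 keeps a branched group of similar bulk on the carbonyl carbon but drops the oxygen; no measured step removes that oxygen, so its effect is unknown here. The expectation is therefore a number near that of compound 3, with the step of a 1.5-fold lower number from compound 3 to compound 4 (0.17 log units; within the scatter) expected to stay close to the scatter. Compound 4 is estimated at 15000 nM, range 4000 nM to 50000 nM.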

Compound 4, half-maximal inhibitory concentration: > 200000 nM
Compound 4: no number, only a limit; the forecaster's own chance of this, stated with the estimate: 15%; middle value at least 13-fold (1.12 log units) away from the limit.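

Compound 4 stands at a limit of the assay and not at a number: the limit of > 200000 nM in this assay, at which 1 of the 4 values shown sits.

In this assay, the change to tert-butyl on this carbonyl carbon gives an at least 9.0-fold higher number from compound 3 to compound 4 (0.95 log units; beyond the scatter), and the comparisons with the ethoxy and dimethylamino groups give an at least 66-fold higher number from compound 2 to compound 4 (1.82 log units; beyond the scatter) and an at least 40-fold higher number from compound 1 to compound 4 (1.60 log units; beyond the scatter). Heavy-atom count alone does not order these groups, since tert-butyl has 4 heavy atoms against 5 in isobutoxy, and compound 4 goes against the reading of the step to compound 3 as a rise that follows a growing group.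

The compounds shown do not separate the loss of the oxygen from the change in branching, and a tert-butoxy group or an isobutyl group on the same carbonyl carbon would address that split directly. As far as these compounds go, how far compound 4 lies past its limit also remains open, so the three steps stay bounds, and the full size of each is unknown.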